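Weak inhibitors: bromo for methyl on the aryl ring

The source may report more compounds than this note shows. Statements on the series, on what has been measured and on what is new or still open speak of the compounds shown alone.

Measured compounds:
compound 1 `O=C1C=CC(OCC(F)(F)F)N1c1cc(F)cc(F)c1`: 7840 nM
compound 2 `Cc1ccc(N2C(=O)C=CC2OCC(F)(F)F)cc1`: 15800 nM

Both compounds share one core and differ only in the aryl group. In a functional assay on MDA-MB-231 cells (Homo sapiens) for inhibition (on this read-out higher numbers stand for weaker inhibition and lower numbers for stronger inhibition), compound 1 gives 7840 nM and compound 2 gives 15800 nM; the two numbers lie within the scatter of each other, so neither can be ranked against the other. Compound 2 carries the higher of the two numbers as read.

Compound 3 `O=C1C=CC(OCC(F)(F)F)N1c1ccc(Br)cc1` is not yet measured. It differs from compound 2 by bromo in place of methyl on an aromatic carbon. For the measured compounds named here, no measured pair tells how such a change acts in this assay; the expected step is none beyond the scatter, in either direction. Compound 3 is therefore estimated at 12000 nM, in the range 3500 nM to 40000 nM. The step this estimate means is a 1.3-fold lower number from compound 2 to compound 3 (0.12 log units; within the scatter), which is an expectation only.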

Compound 3, half-maximal inhibitory concentration: 7570 nM
For compound 3 the middle estimate is 1.6-fold (0.20 log units) above the measured one, and the stated range covers the measured number.
By their numbers in this assay, from the lowest: compounds 3, 1 and 2 (each within the scatter of the next, the first and the last beyond it).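

At this position, on an aromatic carbon para to a large group, bromo in place of methyl gives a modest shift in this assay (a 2.1-fold lower number from compound 2 to compound 3 (0.32 log units; beyond the scatter)). This is the only single-place step among the compounds shown, and it is the first sign that this position affects the read-out at all, though compound 3 remains a weak inhibitor. No measurement at hand accounts for the step.

Still open, from the compounds shown here alone, is how an amine, a carboxylic acid or a longer chain would read at this position. Also open, going by these compounds, is whether the same exchange would carry over to other substitution on the aryl ring.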